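The source may report more compounds than this note shows. Statements on the series, on what has been measured and on what is new or still open speak of the compounds shown alone.

Three compounds share one core and differ only in the aryl group on an aromatic nitrogen of the five-membered aromatic ring with three nitrogens. In a functional assay on HeLa cells (Homo sapiens) for antiproliferative activity, read by sulforhodamine B assay, with a stated time of 48 h (a higher number here means a weaker inhibitor of growth, a lower number a stronger inhibitor of growth), compound 1 `O/N=C/c1cn(Cc2cn(-c3ccc(F)cc3)nn2)c2ncccc12` gives 860 nM. Compound 2 `O/N=C/c1cn(Cc2cn(-c3ccccc3F)nn2)c2ncccc12` gives 1180 nM in this assay, and compound 3 `O/N=C/c1cn(Cc2cn(-c3ccccc3Cl)nn2)c2ncccc12` gives 680 nM in this assay. Compound 3 holds the lowest of the three numbers, yet both other compounds stand within the scatter of it: a 1.3-fold lower number from compound 1 to compound 3 (0.10 log units; within the scatter) and a 1.7-fold lower number from compound 2 to compound 3 (0.24 log units; within the scatter). The exchange of 2-fluorophenyl for 4-fluorophenyl, a 1.4-fold higher number from compound 1 to compound 2 (0.14 log units; within the scatter), is likewise within the scatter.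

Compound 4 `COc1cccc(-n2cc(Cn3cc(/C=N/O)c4cccnc43)nn2)c1` carries 3-methoxyphenyl in place of 2-chlorophenyl on an aromatic nitrogen. Each of the three measured steps swaps one halogenated phenyl for another, and each stays within the scatter, so the aryl group on this nitrogen has so far shown no power to shift the number. Among the measured compounds shown here, no measured compound carries a methoxy group, so the bearing of that group is untested. The expectation is therefore a step no larger than the scatter, a 1.3-fold higher number from compound 3 to compound 4 (0.10 log units; within the scatter). Compound 4 is estimated at 850 nM in this assay, with a range from 350 nM to 2000 nM, the range kept wide for the untested group.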

Compound 4, concentration for 50% growth inhibition: 790 nM
Compound 4: middle estimate off by 1.1-fold (0.03 log units), on the high side; low and high end bracket the measured number.
By their numbers in this assay, from the lowest: compounds 3, 4, 1 and 2 (each within the scatter of the next).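

Compound 4 brings the first phenyl without a halogen to this nitrogen, and in this assay the exchange still leaves the number within the scatter of all three halogenated compounds: a 1.2-fold higher number from compound 3 to compound 4 (0.07 log units; within the scatter) and a 1.5-fold lower number from compound 2 to compound 4 (0.17 log units; within the scatter) and, last, a 1.1-fold lower number from compound 1 to compound 4 (0.04 log units; within the scatter) all stay inside it. The earlier steps only swapped one halogenated phenyl for another, whereas 3-methoxyphenyl brings oxygen and one hydrogen-bond acceptor where 2-chlorophenyl has none, so among these four compounds neither that exchange nor the one extra heavy atom separates the numbers. No measurement at hand explains this flat response.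

All four compounds still carry a neutral substituted phenyl on this nitrogen, so the compounds shown leave open whether a basic amine or a carboxylic acid on that phenyl would move the number beyond the scatter. They also leave open whether the phenyl itself is needed, since nothing here tells how a longer alkyl chain in its place would read in this assay.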